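A few compounds are considered here, and "the series" means these few. Any claim that something is new, unique, unknown or untested is made for them only; others in the source may bear on it.

Measured so far in a functional assay on MCF7 cells (Homo sapiens) for antiproliferative activity, read by MTT assay, with a stated time of 48 h; on this read-out lower numbers stand for stronger inhibition and higher numbers for weaker inhibition:
compound 1 `CC(=O)Nc1ccc(-n2nncc2CN2C(=O)C3(C(C#N)=C(N)Oc4c3c3nc5ccccc5nc3c3ccccc43)c3ccccc32)cc1` — compound 1 gives > 50000 nM, a limit of the assay.
compound 2 `Cc1ccc(-n2nncc2CN2C(=O)C3(C(C#N)=C(N)Oc4c3c3nc5ccccc5nc3c3ccccc43)c3ccccc32)c(C)c1` — compound 2 gives > 50000 nM, a limit of the assay.
compound 3 `N#CC1=C(N)Oc2c(N)cc3nc4ccccc4nc3c2C12C(=O)N(Cc1cnnn1-c1cccc(Br)c1)c1ccccc12` — compound 3 gives > 50000 nM, a limit of the assay.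

Compound 3 therefore stands at the limit of this assay, and no number places it relative to the other two, whose values are limits as well. Among the compounds with values here, the only step between measured compounds, a step that the two limits leave unreadable from compound 1 to compound 2, cannot be read because the limit of > 50000 nM in this assay, at which 3 of the 3 values shown sit, holds both of its ends; it shows that exchanging one aryl group for another on the aromatic nitrogen of the triazole left both compounds beyond the reach of the assay.

Compound 4 `N#CC1=C(N)Oc2c(N)cc3nc4ccccc4nc3c2C12C(=O)N(Cc1cnnn1-c1ccc(Cl)cc1Cl)c1ccccc12` differs from compound 3 by 2,4-dichlorophenyl in place of 3-bromophenyl on an aromatic nitrogen. Within the data shown here, no measured step bears directly on this change. Among the measured compounds shown here, the one measured step is unreadable, and every value shown sits at the limit, so the series gives no sign that a change of the aryl group on this nitrogen moves this assay within a readable range.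

For compound 4 the expectation is therefore that the assay again reports a limit rather than a number, with an estimated value of 50000 nM and a range of 20000 nM to 150000 nM. The step of a number no higher from compound 3 to compound 4 (the limit leaves the size open) is expected to be none beyond the scatter.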

Compound 4, half-maximal inhibitory concentration: > 50000 nM
Compound 4: a limit, no number; the forecaster's own chance of this, stated with the estimate: 80%; the middle value lies on the limit itself.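

Compound 4 gives > 50000 nM and this is a limit of the assay, so no step can be read between compound 3 and compound 4 because both ends sit at a limit: the limit of > 50000 nM in this assay, at which 4 of the 4 values shown sit. In this assay the compounds shown leave open whether any aryl group on this nitrogen, or any change to the shared core, gives a number rather than a limit.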